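The compounds below may be only part of what the source reports. "The series", "measured", "known", "first", "only" and "open" are said of these compounds alone.

Measured compounds:
Compound 1, `Cc1nc2c(s1)C(=O)C=C(Nc1ccc(OC(F)(F)F)cc1)C2=O`: in a functional assay on HepG2 cells (Homo sapiens) for cytotoxicity, read by MTT assay (on this read-out higher numbers stand for weaker inhibition and lower numbers for stronger inhibition), compound 1 gives > 100 ug/mL, which is a limit of the assay.
Compound 2, `Cc1nc2c(s1)C(=O)C=C(Nc1ccc(C(F)(F)F)cc1)C2=O`: in this assay compound 2 gives > 100 ug/mL, which is again a limit of the assay.

Compound 2 therefore stands only at a limit, with no number of its own. Among the compounds with values here, the one measured step that reaches it, a step that the two limits leave unreadable from compound 1 to compound 2, could not be read in size because both values sit at the limit of > 100 ug/mL in this assay, at which 2 of the 2 values shown sit.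

Compound 3, `CCOc1ccc(NC2=CC(=O)c3sc(C)nc3C2=O)cc1`, differs from compound 2 by ethoxy in place of trifluoromethyl on an aromatic carbon. Within the data shown here, no measured step involves an ethoxy group, and the only step at this position gave no readable size, so nothing on hand points to a change beyond the scatter. For compound 3 the expected value in this assay is 120 ug/mL, between 40 ug/mL and 400 ug/mL. The expected step is a step that the limit leaves unreadable from compound 2 to compound 3, and the result is most likely to be reported once more only as a limit.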

Compound 3, half-maximal inhibitory concentration: 4.9 ug/mL
Compound 3: middle estimate off by 24-fold (1.39 log units), on the high side, outside the stated range (below it).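

In this assay this position turns out to be able to move the read-out: ethoxy in place of trifluoromethyl gives an at least 20-fold lower number from compound 2 to compound 3 (1.30 log units; beyond the scatter), and ethyl in place of trifluoromethyl on the oxygen gives an at least 20-fold lower number from compound 1 to compound 3 (1.30 log units; beyond the scatter). Both steps lie beyond the scatter, and compound 3 is the only one of the three with a number of its own. The step between compound 1 and compound 2 still cannot be read, because both compounds sit at a limit of the assay: the limit of > 100 ug/mL in this assay, at which 2 of the 3 values shown sit.

These three compounds cannot separate what the ethyl group itself contributes from what the loss of the fluorine atoms contributes. They also leave open how a methoxy group, a longer alkoxy chain or an amine at this position would read.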